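Trifluoromethyl for chloro on the aryl of compound 1

A few compounds are considered here, and "the series" means these few. Any claim that something is new, unique, unknown or untested is made for them only; others in the source may bear on it.

Compound 1 `O=C(Nc1cccc(-n2cc(-c3ccncc3)c(-c3ccc(Cl)c(O)c3)n2)c1)Nc1ccc(Cl)c(Cl)c1` carries a 3,4-dichlorophenyl group at one end of the shared core. In a functional assay on DU-145 cells (Homo sapiens) for inhibition, read by sulforhodamine B assay, with a stated time of 48 h (on this read-out higher numbers stand for lower toxicity in this test and lower numbers for higher toxicity in this test), compound 1 gives > 32500 nM, which is a limit of the assay and not a number. Compound 2 `COc1cc(-c2nn(-c3cccc(NC(=O)c4ccc(Cl)c(C(F)(F)F)c4)c3)cc2-c2ccncc2)ccc1Cl` belongs to the same series. In this assay compound 2 gives > 32500 nM, again a limit. Compound 3 `COc1cc(-c2nn(-c3cccc(NC(=O)Nc4cccc(C(F)(F)F)c4)c3)cc2-c2ccncc2)ccc1Cl` differs from compound 2 in one place. In this assay compound 3 gives > 50000 nM, also a limit. Within the data shown here, the only single-place step among the measured compounds, a step that the two limits leave unreadable from compound 2 to compound 3, is thus of unreadable size; two of the three values sit at the limit of > 32500 nM in this assay, at which 2 of the 3 values shown sit, and one at the limit of > 50000 nM in this assay, at which 1 of the 3 values shown sits. Compound 4 `O=C(Nc1cccc(-n2cc(-c3ccncc3)c(-c3ccc(Cl)c(O)c3)n2)c1)Nc1ccc(Cl)c(C(F)(F)F)c1` differs from compound 1 by trifluoromethyl in place of chloro on an aromatic carbon. Among the measured compounds shown here, no measured step bears on this change, and every value in the set is a limit. Expected, then, is a step that the limit leaves unreadable from compound 1 to compound 4, no step beyond the scatter, with this assay likely to return a limit once more. Compound 4 is estimated at 50000 nM, within 20000 nM to 150000 nM.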

Compound 4, concentration lethal to 50% of the cells: 25100 nM
For compound 4 the middle estimate is 2.0-fold (0.30 log units) above the measured one; measured number inside the range.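

Trifluoromethyl in place of chloro on this aromatic carbon, ortho to a chloro group, gives an at least 1.2-fold lower number from compound 1 to compound 4 (0.11 log units; that floor lies within the scatter). Compound 4 is the only compound shown with a number rather than a limit in this assay, so this position accepts the change with a value that can be read, although the true size of the step stays undefined. Compound 1 remains a limit and not a number: the limit of > 32500 nM in this assay, at which 2 of the 4 values shown sit.

As far as these compounds go, whether a nitrile or a methyl group on the same carbon would also give a readable value in this assay stays open. No single-place link joins compound 4 to compound 2 or compound 3, so the hydroxy and methoxy forms of the other aryl group cannot be compared here.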